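The source may hold more compounds than are shown below. What is called first, only, known or untested is meant among the compounds shown, and "the series" means these compounds.

Measured compounds:
- compound 1 `CC(C)n1ncc2c(C(=O)Nc3ccccc3)cccc21` — 38500 nM
- compound 2 `CC(C)n1ncc2c(C(=O)Nc3cccnc3)cccc21` — > 40000 nM
- compound 3 `CC(C)n1ncc2c(C(=O)NC3CCCC3)cccc21` — > 40000 nM

In a functional assay on MGC-803 cells (Homo sapiens) for inhibition, read by MTT assay, with a stated time of 72 h (a lower number here means a stronger inhibitor, a higher number a weaker inhibitor), compound 1 gives 38500 nM, a weak number. For compound 2 this assay gives only a limit, > 40000 nM. For compound 3 this assay again gives only a limit, > 40000 nM. So compound 3 stands at the limit of this assay, and no number for it is known; it shares that position with compound 2, as shown by the limit of > 40000 nM in this assay, at which 2 of the 3 values shown sit. The two steps from compound 1 are an at least 1.0-fold higher number from compound 1 to compound 2 (0.01 log units; that floor lies within the scatter) and an at least 1.0-fold higher number from compound 1 to compound 3 (0.01 log units; that floor lies within the scatter), both floors that lie within the scatter. The step that the two limits leave unreadable from compound 2 to compound 3 cannot be read, since both ends are limits.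

Compound 4 `CC(C)n1ncc2c(C(=O)NCc3ccccc3)cccc21` is not yet measured in this assay. The change is benzyl in place of cyclopentyl on an amide-type nitrogen. For the measured compounds named here, no measured step carries a benzyl on this amide-type nitrogen, so the only bearing steps are the two from compound 1, which show that swapping the phenyl for a pyridin-3-yl or a cyclopentyl leaves the compound at or past the limit. The step of a number no higher from compound 3 to compound 4 (the limit leaves the size open) is therefore expected to be small, with no direction readable beyond the scatter. For compound 4 the estimate in this assay is 40000 nM, with a range from 15000 nM to 120000 nM, and it is expected that a limit rather than a number is the likely outcome.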

Compound 4, half-maximal inhibitory concentration: > 40000 nM
Compound 4: no number, only a limit (the forecaster's own chance of this, stated with the estimate: 65%); the middle value lies on the limit itself.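

In this assay, benzyl on the amide-type nitrogen is a third replacement for phenyl that ends at a limit, adding a group with a carbon-only aromatic ring set one carbon away from the nitrogen to the pyridin-3-yl and cyclopentyl already there: the limit of > 40000 nM in this assay, at which 3 of the 4 values shown sit. Against phenyl, the result is an at least 1.0-fold higher number from compound 1 to compound 4 (0.01 log units; that floor lies within the scatter), so no loss relative to compound 1 can be claimed, and compound 1, at 38500 nM, remains the only compound in the series with a number. The steps among compound 2, compound 3 and compound 4 cannot be read, since all three ends are limits, so pyridin-3-yl, cyclopentyl and benzyl cannot be ordered at this position.

As far as these compounds go, it remains open whether any group on this amide-type nitrogen gives a number clearly lower than that of compound 1, for example a phenyl carrying an amine or a carboxylic acid, or a longer chain ending in phenyl. The compounds shown also leave open how far the shared core itself, rather than the group on this nitrogen, sets the level of the series in this assay.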